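Swapping Chloro for Methoxy on the Amide-Side Ring

The compounds below may be only part of what the source reports. "The series", "measured", "known", "first", "only" and "open" are said of these compounds alone.

Of the compounds shown here, three built on one shared core have been measured in a functional assay on HCT-116 cells (Homo sapiens) for cytotoxicity, read by MTT assay, with a stated time of 48 h; on this read-out higher numbers stand for weaker inhibition and lower numbers for stronger inhibition. Compound 1 `COc1ccc(NC(=O)c2cn(-c3ccccc3)nc2-c2ccc(C)cc2)cc1` gives 1450 nM. Compound 2 `COc1ccc(NC(=O)c2cn(-c3ccccc3)nc2-c2ccc(OC)cc2)cc1` gives 1520 nM. Compound 3 `O=C(Nc1ccc(Cl)cc1)c1cn(-c2ccccc2)nc1-c1ccc(Cl)cc1` gives 2990 nM, the highest of the three numbers; its gap to compound 2 lies within the scatter, while its gap to compound 1 lies just beyond it. For the measured compounds named here, the only step between two measured compounds that differ in one place, a 1.0-fold higher number from compound 1 to compound 2 (0.02 log units; within the scatter), concerns the ring attached directly to the core, not the ring carrying the amide nitrogen.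

Compound 4 `COc1ccc(NC(=O)c2cn(-c3ccccc3)nc2-c2ccc(Cl)cc2)cc1` differs from compound 3 by methoxy in place of chloro on an aromatic carbon. Going by the values given here, no measured step tests this exact change. What the numbers do show is that the (4-methoxyphenyl)amino group of compound 4 is also carried by compound 1, which gives 1450 nM, and by compound 2, which gives 1520 nM, with compound 3 sitting higher than compound 1 in this assay. Compound 4 is therefore expected to give about 1800 nM, within a range from 900 nM to 3600 nM. The expected step is a 1.7-fold lower number from compound 3 to compound 4 (0.22 log units; within the scatter), small enough that it may not rise beyond the scatter.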

Compound 4, half-maximal inhibitory concentration: 1330 nM
Estimate against measurement, compound 4: 1.4-fold (0.13 log units) above, and the stated range covers the measured number.
By their numbers in this assay, from the lowest: compounds 4, 1, 2 and 3 (each within the scatter of the next, the first and the last beyond it).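

In this assay, compound 4 gives the first direct test of the ring carrying the amide nitrogen: with the 4-chlorophenyl group on the other ring held fixed, changing (4-chlorophenyl)amino to (4-methoxyphenyl)amino gives a 2.2-fold lower number from compound 3 to compound 4 (0.35 log units; beyond the scatter) in this series. With (4-methoxyphenyl)amino held fixed, changes on the other ring give a 1.1-fold lower number from compound 2 to compound 4 (0.06 log units; within the scatter) and a 1.1-fold lower number from compound 1 to compound 4 (0.04 log units; within the scatter), so among compounds 1, 2 and 4, chloro, methyl and methoxy on that ring cannot be told apart. Nothing available here accounts for this difference between the two rings.

The shown compounds leave open whether the effect of the methoxy-for-chloro swap on the amide-side ring holds when the other ring carries methyl or methoxy. They also leave open how an amine, a hydroxyl or a longer chain such as ethoxy would compare with methoxy on that ring.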